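Removing the Quinolinyl Group from Compound 2

The source may report more compounds than this note shows. Statements on the series, on what has been measured and on what is new or still open speak of the compounds shown alone.

Compound 1 `CC(C)(C)c1cc(-c2cc(=O)c3ccc(OCc4ccc(Cl)cc4)cc3o2)cc(C(C)(C)C)c1O`, in a functional assay for inhibition; a lower number here means a stronger inhibitor, a higher number a weaker inhibitor: 7000 nM.
Compound 2 `CC(C)(C)c1cc(-c2cc(=O)c3ccc(OCc4ccc5ccccc5n4)cc3o2)cc(C(C)(C)C)c1O`, in this assay: 3000 nM.
Compound 3 `CCOC(=O)C(C)(C)Oc1ccc2c(=O)cc(-c3cc(C(C)(C)C)c(O)c(C(C)(C)C)c3)oc2c1`, in this assay: 3000 nM.

Compound 2 stands level with compound 3 at the digits reported, and together they hold the lowest of the three numbers; its nearest neighbour is compound 3, with no change at the digits printed from compound 2 to compound 3 (within the scatter), while compound 1 lies furthest off, with a 2.3-fold lower number from compound 1 to compound 2 (0.37 log units; beyond the scatter).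

Compound 4 `COc1ccc2c(=O)cc(-c3cc(C(C)(C)C)c(O)c(C(C)(C)C)c3)oc2c1` differs from compound 2 in one place: hydrogen in place of quinolin-2-yl on a saturated chain carbon bound to an oxygen on an aromatic ring. Within the data shown here, two measured steps bear on this site. Exchanging one aryl for another on the same chain carbon gave a 2.3-fold lower number from compound 1 to compound 2 (0.37 log units; beyond the scatter), a modest shift, and replacing the whole group on the oxygen gave no change at the digits printed from compound 2 to compound 3 (within the scatter). Neither step cuts the group back to hydrogen, so the data give no direct measure of that loss. The surrounding numbers suggest a small shift at most, if anything toward a weaker inhibitor, and compound 4 is therefore expected to show a 2.0-fold higher number from compound 2 to compound 4 (0.30 log units; within the scatter). The estimate for compound 4 is 6000 nM, with a range of 2000 nM to 20000 nM.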

Compound 4, half-maximal inhibitory concentration: 1000 nM
Compound 4: middle estimate off by 6.0-fold (0.78 log units), on the high side; the whole stated range lies above it.
By their numbers in this assay, from the lowest: compound 4; then compounds 2 and 3 (each within the scatter of the next); then compound 1.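

Cutting the group on the oxygen back to methyl did not cost inhibition in this assay: the number fell, with a 3.0-fold lower number from compound 2 to compound 4 (0.48 log units; beyond the scatter), so the quinolin-2-yl is not required for activity at this position. The larger groups on this oxygen all compare poorly with methyl, with a 3.0-fold lower number from compound 3 to compound 4 (0.48 log units; beyond the scatter) and a 7.0-fold lower number from compound 1 to compound 4 (0.85 log units; beyond the scatter), which makes compound 4 the strongest inhibitor of the four, and neither aryl group nor the ester-bearing group offers any gain over methyl. Nothing measured here accounts for this ordering.

The compounds shown leave open whether the number would keep falling with a free hydroxyl at this position, or would rise again with an ethyl group on the oxygen. They also leave open whether a carboxylic acid in place of the ethyl ester of compound 3 would alter its standing against compound 4.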